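Inverting the configuration of compound 3

This account rests on a few compounds, and the source may have more. Where it says the series, first, only, none or still open, it means among the compounds named here.

In an ADME assay on the whole organism (Rattus norvegicus) for metabolic stability, at a dose of 1 mg/kg by the intravenous route (on this read-out higher numbers stand for fast clearance and lower numbers for slow clearance), compound 1 `COc1ccc(F)cc1-c1ccnc2[nH]c(C3=CCN([C@H]4CC[C@H](C(=O)O)CC4)CC3)cc12` gives 0.00967 mL/min/kg, compound 2 `COc1ccc(F)cc1-c1ccnc2[nH]c(C3=CCN([C@H]4CC[C@@H](C(=O)O)CC4)CC3)cc12` gives 0.0217 mL/min/kg and compound 3 `COc1ccc(F)cc1-c1c(F)cnc2[nH]c(C3=CCN([C@H]4CC[C@H](C(=O)O)CC4)CC3)cc12` gives 0.0105 mL/min/kg. Compound 3 thus stands close to compound 1, with compound 2 above both. Compound 4 `COc1ccc(F)cc1-c1c(F)cnc2[nH]c(C3=CCN([C@H]4CC[C@@H](C(=O)O)CC4)CC3)cc12` relates to compound 3 as follows: the two compounds have the same atoms and bonds and differ only in configuration as drawn: 2 of 2 stereo elements differ (all stereocentres are inverted: mirror images); a stereocentre at a saturated ring carbon is drawn r in compound 3 and s in compound 4; a stereocentre at a saturated ring carbon is drawn r in compound 3 and s in compound 4. Going by the values given here, the one measured change of this kind is a 2.2-fold higher number from compound 1 to compound 2 (0.35 log units; beyond the scatter), a modest step beyond the scatter, and it rests on (the fact that compounds 1 and 2 differ only in the configuration as drawn). Fluoro in place of hydrogen gave a 1.1-fold higher number from compound 1 to compound 3 (0.04 log units; within the scatter), so the fluoro compounds may well repeat that step. A similar modest rise is therefore expected, an estimated 2.2-fold higher number from compound 3 to compound 4 (0.34 log units; beyond the scatter). The estimate for compound 4 is 0.023 mL/min/kg, with an expected range from 0.011 mL/min/kg to 0.048 mL/min/kg.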

Compound 4, clearance: 0.0157 mL/min/kg
Estimate against measurement, compound 4: 1.5-fold (0.17 log units) above, and the stated range covers the measured number.
By their numbers in this assay, from the lowest: compounds 1, 3, 4 and 2 (each within the scatter of the next, the first and the last beyond it).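

On the fluoro pair, inverting the configuration gives a step within the scatter (a 1.5-fold higher number from compound 3 to compound 4 (0.17 log units; within the scatter)), so the rise seen without fluoro (a 2.2-fold higher number from compound 1 to compound 2 (0.35 log units; beyond the scatter)) is not clearly repeated in this assay. Fluoro in place of hydrogen on an aromatic carbon also stays within the scatter in the second configuration (a 1.4-fold lower number from compound 2 to compound 4 (0.14 log units; within the scatter)), and the two fluoro steps agree: the same change on two cores in this assay, a 1.1-fold higher number (0.04 log units; within the scatter) from compound 1 to compound 3 and a 1.4-fold lower number (0.14 log units; within the scatter) from compound 2 to compound 4, 1.5-fold (0.18 log units) apart, within the scatter of two such steps.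

The compounds shown leave open whether a chloro or nitrile group in place of this fluoro would give a similar clearance. They also leave open how an amide in place of the carboxylic acid would behave.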